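Aryl variation on the shared core: methoxy for trifluoromethyl

The compounds below may be only part of what the source reports. "The series", "measured", "known", "first", "only" and "open" are said of these compounds alone.

Of the compounds shown here, three on the shared core have been measured. Compound 1 `Clc1ccc(C2=NN(c3ccc(-c4ccccc4)nn3)C(c3ccccc3)C2)cc1` gives 8750 nM in a functional assay on HepG2 cells (Homo sapiens) for antiproliferative activity, read by MTT assay, with a stated time of 24 h; on this read-out lower numbers stand for stronger inhibition and higher numbers for weaker inhibition. Compound 2 `Clc1ccc(C2=NN(c3ccc(-c4ccccc4)nn3)C(c3ccc(Cl)cc3)C2)cc1` gives 10000 nM in this assay, and compound 3 `FC(F)(F)c1ccc(C2CC(c3ccc(Cl)cc3)=NN2c2ccc(-c3ccccc3)nn2)cc1` gives 8330 nM in this assay. The single-point steps between them are a 1.1-fold higher number from compound 1 to compound 2 (0.06 log units; within the scatter), a 1.1-fold lower number from compound 1 to compound 3 (0.02 log units; within the scatter) and a 1.2-fold lower number from compound 2 to compound 3 (0.08 log units; within the scatter); all three numbers sit within the scatter of one another, so compound 3 cannot be set apart from compound 1 or compound 2 on these data.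

Compound 4 `COc1ccc(C2CC(c3ccc(Cl)cc3)=NN2c2ccc(-c3ccccc3)nn2)cc1` differs from compound 3 in one place: methoxy in place of trifluoromethyl on an aromatic carbon, on an aromatic carbon of a six-membered aromatic ring of carbon only, para to a large group; cut one bond further out this reads 4-(trifluoromethyl)phenyl to 4-methoxyphenyl. The measured steps that bear on this position are a 1.1-fold lower number from compound 1 to compound 3 (0.02 log units; within the scatter), a 1.2-fold lower number from compound 2 to compound 3 (0.08 log units; within the scatter) and a 1.1-fold higher number from compound 1 to compound 2 (0.06 log units; within the scatter), each within the scatter. Among the measured compounds shown here, no measured compound carries methoxy, so the new group itself is untested here. On that basis no step beyond the scatter is expected in this assay for compound 4.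

Compound 4 is therefore estimated at 8500 nM, with a range from 4000 nM to 18000 nM. The expected step is a 1.0-fold higher number from compound 3 to compound 4 (0.01 log units; within the scatter), essentially flat.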

Compound 4, half-maximal inhibitory concentration: > 100000 nM
Compound 4 ended at the assay's limit (the forecaster's own chance of this, stated with the estimate: 10%); middle value at least 11-fold (1.07 log units) away from the limit.
By their numbers in this assay, from the lowest: compounds 3, 1 and 2 (each within the scatter of the next). At a limit, above all of these: compound 4.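

In this assay, among the compounds shown here, this place on the six-membered aromatic ring of carbon only, para to a large group, is not indifferent to every substituent, as hydrogen, chloro and trifluoromethyl had suggested: methoxy is the first group here to give a change beyond the scatter. That change stands against all three earlier groups, with an at least 12-fold higher number from compound 3 to compound 4 (1.07 log units; beyond the scatter), an at least 10-fold higher number from compound 2 to compound 4 (1.00 log units; beyond the scatter) and an at least 11-fold higher number from compound 1 to compound 4 (1.05 log units; beyond the scatter), so compounds 1, 2 and 3 stay together within the scatter while compound 4 alone stands apart. The value of compound 4, > 100000 nM, is a limit of the assay and not a number, so each of these steps gives only a lower bound on its size: the limit of > 100000 nM in this assay, at which 1 of the 4 values shown sits.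

On these data alone, with methoxy as the only oxygen-bearing substituent at this place, it remains open whether a hydroxyl, an ethoxy or a longer alkoxy chain would sit with compound 4 or with compounds 1, 2 and 3, and the same holds for an amine. The data also give no cause for the step, and they do not show whether methoxy would have the same outcome on a core carrying a different group in place of the 4-chlorophenyl.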